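Exchanging 1,1-dioxothian-4-yl for 2-methoxyphenyl in compound 1

This account rests on a few compounds, and the source may have more. Where it says the series, first, only, none or still open, it means among the compounds named here.

In a physicochemical assay for lipophilicity, read by HPLC, at pH 7.4 (a higher number here means a more lipophilic compound, a lower number a more polar compound), compound 1 `CCC/N=C1\S/C(=C\c2ccc(O)c(Cl)c2)C(=O)N1C1CCS(=O)(=O)CC1` gives 2.6. Among the compounds with values here, this is the lowest of the three numbers measured so far, and it lies beyond the scatter from the other two, compound 2 `CCC/N=C1\S/C(=C\c2ccc(O)c(C(F)(F)F)c2)C(=O)N1c1ccccc1C` at 3.8 and compound 3 `CCC/N=C1\S/C(=C\c2ccc(O)c(Br)c2)C(=O)N1c1ccccc1C` at 3.9.

Compound 4 `CCC/N=C1\S/C(=C\c2ccc(O)c(Cl)c2)C(=O)N1c1ccccc1OC` differs from compound 1 in one place, with 2-methoxyphenyl in place of 1,1-dioxothian-4-yl on an amide-type nitrogen in a ring.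

Within the data shown here, no measured step shows this exchange directly. Among the measured compounds shown here, the only step available is bromo in place of trifluoromethyl on an aromatic carbon, a number 0.10 log units higher from compound 2 to compound 3 (within the scatter), and it concerns a different place in the molecule. The better guide is indirect. Compound 2 and compound 3 also carry a six-membered aromatic ring of carbon only on that nitrogen, and both stand well above compound 1. For the measured compounds named here, they differ from compound 1 in other ways too, and their aromatic group is not the one in compound 4, so this comparison gives only a rough size.

An upward step beyond the scatter is therefore expected in this assay, estimated as a number 1.00 log units higher from compound 1 to compound 4 (beyond the scatter). Compound 4 is expected at 3.6, with an estimated range from 3.2 to 4.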

Compound 4, distribution coefficient: 3.3
For compound 4 the middle estimate is 0.30 log units above the measured one; measured number inside the range.
By their numbers in this assay, from the lowest: compound 1; then compound 4; then compounds 2 and 3 (each within the scatter of the next).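

Within the data shown here, this is the first direct reading at the amide-type nitrogen in a ring. With the rest of compound 1 unchanged, placing 2-methoxyphenyl there in place of 1,1-dioxothian-4-yl gives a number 0.70 log units higher from compound 1 to compound 4 (beyond the scatter) in this assay, so the number at this position can move beyond the scatter even though the entering and leaving groups have the same heavy-atom count. The exchange replaces a six-membered non-aromatic ring with a hetero atom and double bonds outside aromatic rings by a six-membered aromatic ring of carbon only, and nothing available indicates which of these differences accounts for the step.

The compounds shown do not separate the aromatic ring from its methoxy group, and a plain phenyl or a 2-methylphenyl on this nitrogen, with the rest of compound 4 unchanged, would be the direct comparison for that question. Going by these compounds, it also remains open how the number would respond at this position to a ring carrying an amine, such as piperidin-4-yl, or to an aromatic ring carrying a carboxylic acid.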